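A few compounds are considered here, and "the series" means these few. Any claim that something is new, unique, unknown or untested is made for them only; others in the source may bear on it.

In an ADME assay on MT4 cells (Homo sapiens) for cytotoxicity, read by spectrophotometry, with a stated time of 5 days (a lower number here means that less compound is tolerated, a higher number that more compound is tolerated), three compounds have been measured so far: compound 1 `Cc1ccc2c(c1)/C(=N/NC(=S)NO)C(=O)N2CN1CCN(c2ccc(Cl)cc2)CC1` gives 335000 nM, compound 2 `Cc1ccc2c(c1)/C(=N/NC(=S)NO)C(=O)N2CN1CCN(c2ccccc2)CC1` gives 420000 nM, and compound 3 `O=C1/C(=N\NC(=S)NO)c2cc(Cl)ccc2N1CN1CCN(c2ccccc2)CC1` gives 273000 nM.

Compound 4 `O=C1/C(=N\NC(=S)NO)c2cc(Cl)ccc2N1CN1CCN(c2ccc(Cl)cc2)CC1` has not yet been measured. It differs from compound 3 by chloro in place of hydrogen on an aromatic carbon. The same change has been made once before, from compound 2 to compound 1: chloro in place of hydrogen on an aromatic carbon. In this assay that pair shows a 1.3-fold lower number from compound 2 to compound 1 (0.10 log units; within the scatter). The two cores themselves differ, compound 3 against compound 2: chloro in place of methyl on an aromatic carbon, with a step of a 1.5-fold lower number from compound 2 to compound 3 (0.19 log units; within the scatter). The place of the entering chloro is described in identical words for both pairs, so the change is the same one. Compound 4 is therefore expected to show a 1.3-fold lower number from compound 3 to compound 4 (0.11 log units; within the scatter), a step of about the size seen in a 1.3-fold lower number from compound 2 to compound 1 (0.10 log units; within the scatter), an expectation resting on that single earlier pair. The estimate for compound 4 is 210000 nM, expected to lie between 120000 nM and 360000 nM.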

Compound 4, half-maximal cytotoxic concentration: 268000 nM
Beside the measured number, compound 4's estimate is 1.3-fold (0.11 log units) below it, within the range that was stated.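

In this assay, the change from phenyl to 4-chlorophenyl gives a 1.0-fold lower number from compound 3 to compound 4 (0.01 log units; within the scatter), and it carries from one core to the other without a measurable difference: the same change on two cores in this assay, a 1.3-fold lower number (0.10 log units; within the scatter) from compound 2 to compound 1 and a 1.0-fold lower number (0.01 log units; within the scatter) from compound 3 to compound 4, 1.2-fold (0.09 log units) apart, within the scatter of two such steps The change of methyl to chloro on an aromatic carbon of the core, read with the 4-chlorophenyl group in place, gives a 1.3-fold lower number from compound 1 to compound 4 (0.10 log units; within the scatter), and it agrees with the earlier step: the same change on two cores in this assay, a 1.5-fold lower number (0.19 log units; within the scatter) from compound 2 to compound 3 and a 1.3-fold lower number (0.10 log units; within the scatter) from compound 1 to compound 4, 1.2-fold (0.09 log units) apart, within the scatter of two such steps This shows that both changes transfer between these two cores within the scatter, but with every step also within the scatter, it does not show that either change has an effect of its own.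

The compounds shown leave open whether a methoxy group or an amine in place of the chloro on the phenyl ring would give a step beyond the scatter. They also leave open whether the agreement would hold on a core bearing a fluoro or a nitrile.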